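The source may hold more compounds than are shown below. What is called first, only, known or untested is meant among the compounds shown, and "the series" means these compounds.

Compound 2 `CC(C)(C)Cc1ccc2nc(N)sc2c1` gives > 10 mg/kg in a functional assay on the whole organism with Rattus norvegicus as the target (a lower number here means that less compound is needed, a higher number that more compound is needed for the effect), as a limit of the assay, not a number. Among the compounds with values here, compound 1 `CCCc1ccc2nc(N)sc2c1` gives 6 mg/kg in this assay and is the only firm number here. Within the data shown here, the only measured step is an at least 1.6-fold higher number from compound 1 to compound 2 (0.22 log units; that floor lies within the scatter) and its floor lies within the scatter, so it is a weak guide. Compound 3 `CCCCCCc1ccc2nc(N)sc2c1` differs by pentyl in place of tert-butyl on a saturated chain carbon bound to an aromatic carbon with pentyl in place of tert-butyl on a saturated chain carbon bound to an aromatic carbon. The estimated step of an at least 1.2-fold lower number from compound 2 to compound 3 (0.09 log units; that floor lies within the scatter) is expected to be small, towards a lower number, and may stay within the scatter. Compound 3 is expected in this assay at 8 mg/kg within an estimated range of 3 mg/kg to 20 mg/kg as a rough guide.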

Compound 3, dose for half-maximal effect: 7 mg/kg
Beside the measured number, compound 3's estimate is 1.1-fold (0.06 log units) above it; low and high end bracket the measured number.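

Putting propyl in place of hydrogen on the chain leaves the dose in this assay within the scatter: a 1.2-fold higher number from compound 1 to compound 3 (0.07 log units; within the scatter). Within the data shown here, this position therefore takes a longer straight chain without a readable change, which the earlier compounds did not show. Pentyl in place of tert-butyl gives an at least 1.4-fold lower number from compound 2 to compound 3 (0.15 log units; that floor lies within the scatter), and this is only a floor, as compound 2 stands at a limit and not a number: the limit of > 10 mg/kg in this assay, at which 1 of the 3 values shown sits.

On these data alone, how far the dose of compound 2 really lies from the others stays open. So does whether an amine or a carboxylic acid on this chain, or a chain longer than pentyl's, would keep the dose.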